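Moving the chlorine on the amino-linked ring of compound 2

The compounds below may be only part of what the source reports. "The series", "measured", "known", "first", "only" and "open" are said of these compounds alone.

Compound 2, `COc1cc(/C=C/C(=O)c2sc(Nc3ccc(Cl)cc3)nc2C)cc(OC)c1OC`, was tested in a functional assay on BGC-823 cells (Homo sapiens) for cytotoxicity, read by MTT assay (a higher number here means a weaker inhibitor, a lower number a stronger inhibitor), and gave only a limit, not a number: > 25000 nM. Compound 1, `COc1cccc(/C=C/C(=O)c2sc(Nc3ccc(Cl)cc3)nc2C)c1`, likewise gives in this assay only a limit, > 25000 nM. Compound 3, `Cc1nc(Nc2ccc(Cl)cc2)sc1C(=O)/C=C/c1ccc(Cl)cc1`, also gives a limit in this assay, > 25000 nM. Going by the values given here, because of the limit of > 25000 nM in this assay, at which 3 of the 3 values shown sit, the one step that joins two measured compounds, a step that the two limits leave unreadable from compound 1 to compound 3, cannot be read in size or direction. Compound 4, `COc1cc(/C=C/C(=O)c2sc(Nc3cccc(Cl)c3)nc2C)cc(OC)c1OC`, differs from compound 2 by 3-chlorophenyl in place of 4-chlorophenyl on a nitrogen on an aromatic ring. Among the compounds with values here, no measured step touches this kind of change. With nothing pointing away from the limit, compound 4 is expected to sit near the same limit, a step that the limit leaves unreadable from compound 2 to compound 4. The estimate for compound 4 is 30000 nM, within 8000 nM to 100000 nM.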

Compound 4, half-maximal inhibitory concentration: 11600 nM
Estimate against measurement, compound 4: 2.6-fold (0.41 log units) above; measured number inside the range.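

In this assay, putting 3-chlorophenyl in place of 4-chlorophenyl on the nitrogen gives an at least 2.1-fold lower number from compound 2 to compound 4 (0.33 log units; beyond the scatter). Going by these compounds alone, the earlier compounds all carry 4-chlorophenyl here and gave no readable number, so this is the first sign that the read-out responds to this ring. The two compounds have the same atoms, joined differently, so where the chlorine sits matters here, not whether it is present.

From the compounds shown here alone, how a nitrile or a methoxy group in place of that chlorine would read remains open. So does whether 3-chlorophenyl would give a readable number alongside the 3-methoxyphenyl of compound 1 or the 4-chlorophenyl of compound 3.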